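Moving the Fluorine on the Amide Aryl Ring

The source may hold more compounds than are shown below. What is called first, only, known or untested is meant among the compounds shown, and "the series" means these compounds.

Measured compounds:
compound 1, `O=C(CN1CCN(S(=O)(=O)c2ccccc2)CC1)Nc1ccccc1F`: 4000 nM
compound 2, `COc1ccc(S(=O)(=O)N2CCN(CC(=O)Nc3ccccc3F)CC2)cc1`: 15400 nM

Going by the values given here, in an in vitro assay on HEK ts201 cells for negative allosteric modulation of Neuronal acetylcholine receptor; alpha3/beta4 (Homo sapiens), read by fluorescence and calcium flux, with a stated time of 1.5 s (a lower number here means a stronger inhibitor, a higher number a weaker inhibitor), compound 2 gives 15400 nM, the highest of the two numbers known. Its nearest neighbour, compound 1, gives 4000 nM in this assay, and the step of a 3.9-fold higher number from compound 1 to compound 2 (0.59 log units; beyond the scatter) is a modest one that lies beyond the scatter.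

Compound 3, `COc1ccc(S(=O)(=O)N2CCN(CC(=O)Nc3ccc(F)cc3)CC2)cc1`, differs from compound 2 by 4-fluorophenyl in place of 2-fluorophenyl on an amide-type nitrogen. Among the compounds with values here, no measured step bears on this change: the only step recorded concerns a methoxy in place of hydrogen on an aromatic carbon on the other side of the shared core and says nothing about which fluorophenyl sits on the amide-type nitrogen. With no guide in either direction, the expected step in this assay is none beyond the scatter, with a wide range to allow for surprise.

Compound 3 is therefore expected to give about 15000 nM in this assay, with a range from 5000 nM to 45000 nM. The estimated step is a 1.0-fold lower number from compound 2 to compound 3 (0.01 log units; within the scatter).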

Compound 3, half-maximal inhibitory concentration: 17100 nM
Compound 3: the middle estimate sits 1.1-fold (0.06 log units) below what was measured; low and high end bracket the measured number.
By their numbers in this assay, from the lowest: compound 1; then compounds 2 and 3 (each within the scatter of the next).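

Swapping 2-fluorophenyl for 4-fluorophenyl on the amide-type nitrogen gives a 1.1-fold higher number from compound 2 to compound 3 (0.05 log units; within the scatter) in this assay, so the two fluorine placements cannot be told apart here. Going by these compounds alone, the earlier compounds spoke only to the other side of the shared core, where adding methoxy to the aromatic ring gave a 3.9-fold higher number from compound 1 to compound 2 (0.59 log units; beyond the scatter); this pair is the one reading at the amide end, and there the change of placement shows no effect beyond the scatter. Nothing shown here offers an explanation for this result.

On these data alone, it remains open whether a plain phenyl or a chlorophenyl on the amide-type nitrogen would read differently from these two fluorophenyl groups. As far as these compounds go, it is also open whether the same swap would read alike on the core of compound 1, which lacks the methoxy group.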